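Shortening the Acyl Chain in a Metabolic Stability Series

The compounds below may be only part of what the source reports. "The series", "measured", "known", "first", "only" and "open" are said of these compounds alone.

Measured so far:
compound 1, `CCOC(=O)c1ccc(/N=N/N(C)C(=O)[C@H](C)NC(C)=O)cc1`: 4.6 h
compound 2, `CCCC(=O)N[C@@H](C)C(=O)N(C)/N=N/c1ccc(C#N)cc1`: 1.1 h

Of the compounds shown here, two have been measured in an ADME assay on a cell-free system (plasma, Homo sapiens) for metabolic stability, read by HPLC; a higher number here means that the compound lasts longer, a lower number that the compound disappears faster. Compound 1 gives 4.6 h, while compound 2 gives 1.1 h, the lower of the two numbers; the gap between them lies beyond the usual scatter of this assay. Compound 3 `CCC(=O)N[C@@H](C)C(=O)N(C)/N=N/c1ccc(C#N)cc1` has not yet been measured. It differs from compound 2 in a single place: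

hydrogen in place of methyl on a saturated chain carbon, two bonds along the chain from a carbonyl carbon

Going by the values given here, no pair of measured compounds shares this exact change, so there is no measured step to lean on. The change removes only one carbon from a short chain, so the expected step in this assay is small, most likely within the scatter, with no clear direction. The step is estimated as a 1.1-fold lower number from compound 2 to compound 3 (0.04 log units; within the scatter). Compound 3 is therefore expected to give about 1 h, within a range from 0.5 h to 2.2 h.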

Compound 3, half-life: 1.3 h
Compound 3: middle estimate off by 1.3-fold (0.11 log units), on the low side, within the range that was stated.
By their numbers in this assay, from the lowest: compounds 2 and 3 (each within the scatter of the next); then compound 1.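

Going by these compounds alone, replacing methyl with hydrogen on a saturated chain carbon, two bonds along the chain from a carbonyl carbon, gives a 1.2-fold higher number from compound 2 to compound 3 (0.07 log units; within the scatter) in this assay, the first measured step at this position. Going from propylcarbonyl to propanoyl therefore leaves the half-life of this pair within the usual scatter, so removing this one carbon does not produce a measurable difference here. Nothing measured on hand offers an explanation for this result.

Still open, on these data alone, is whether a longer chain, or a chain ending in an amine or a carboxylic acid, would move the half-life beyond the scatter at this place. Compound 1 differs from compound 2 and compound 3 in more than one place, so its gap from them cannot be assigned to any single part of the structure.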